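The source may report more compounds than this note shows. Statements on the series, on what has been measured and on what is new or still open speak of the compounds shown alone.

Measured compounds and their numbers:

Compound 1, `O=C(NC1CCCCC1)Oc1cccc(C2=NCCO2)c1`: in an assay on membranes from cerebellum (strain Wistar) for inhibition of Monoglyceride lipase (Rattus norvegicus), read by HPLC, tested at 100 uM (on this read-out higher numbers stand for more inhibition at the one concentration tested (going by the name of the read-out) and lower numbers for less inhibition), compound 1 gives 22%.
Compound 2, `O=C(NC1CCCCC1)Oc1cccc(C2=N[C@@H](Cc3ccccc3)CO2)c1`: compound 2 gives 17%.
Compound 3, `O=C(NC1CCCCC1)Oc1cccc(C2=N[C@H](Cc3ccccc3)CO2)c1`: compound 3 gives 14%.

All three compounds share one core and differ only in the group carried on a saturated ring carbon. Compound 3 shows the lowest of the three numbers, yet the gaps to the others are a number 3 percentage points lower from compound 2 to compound 3 (within the scatter) and a number 8 percentage points lower from compound 1 to compound 3 (within the scatter), so the three numbers cannot be told apart. The close agreement of compounds 2 and 3 fits with the fact that (the fact that compounds 2 and 3 differ only in the configuration as drawn).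

Compound 4, `COC(=O)[C@@H]1COC(c2cccc(OC(=O)NC3CCCCC3)c2)=N1`, differs from compound 3 by methoxycarbonyl in place of benzyl on a saturated ring carbon.

The measured steps that touch this ring carbon are a number 5 percentage points lower from compound 1 to compound 2 (within the scatter) and a number 8 percentage points lower from compound 1 to compound 3 (within the scatter). Both show that putting a benzyl on this carbon, in either configuration, left the number within the scatter. For the measured compounds named here, no measured step places a methoxycarbonyl there, so the new group itself is untested. Given the indifference of this position to the benzyl change, the expectation is no step beyond the scatter: a number 3 percentage points higher from compound 3 to compound 4 (within the scatter) is estimated. Compound 4 is therefore expected to give about 17%, with a range from 5% to 32%.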

Compound 4, a percentage reported as inhibition, at one concentration (the size of the read-out at that concentration, not a potency): 25%
Compound 4: middle estimate off by 8 percentage points, on the low side; low and high end bracket the measured number.
By their numbers in this assay, from the lowest: compounds 3, 2, 1 and 4 (each within the scatter of the next, the first and the last beyond it).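

In this assay, for the compounds shown here, this ring carbon does respond to some changes, since methoxycarbonyl in place of benzyl gives the first step that lies beyond the scatter: a number 11 percentage points higher from compound 3 to compound 4 (beyond the scatter). The step is modest and holds only against the benzyl compound, because the comparison with the hydrogen of compound 1 gives a number 3 percentage points higher from compound 1 to compound 4 (within the scatter), so compound 4 and compound 1 cannot be told apart and the ester gives no measurable gain over the bare ring carbon. The exchange swaps an aromatic ring for a smaller group that carries hydrogen-bond acceptors, but nothing available here ties the step to either of these differences.

From the compounds shown here alone, what stays open is whether the step reflects something the methoxycarbonyl group brings or simply the loss of benzyl, a question that a carboxylic acid, a primary amide or a hydroxymethyl group on the same carbon could help to settle. The mirror-image form of compound 4 would likewise show whether the drawn configuration matters for this group, as the benzyl pair cannot answer that for an ester.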